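A Methoxy Group Changes Place in Compound 4

The source may hold more compounds than are shown below. What is called first, only, known or untested is meant among the compounds shown, and "the series" means these compounds.

In a functional assay on MGC-803 cells (Homo sapiens) for inhibition, read by MTT assay, with a stated time of 72 h (a higher number here means a weaker inhibitor, a lower number a stronger inhibitor), compound 1 `O=C(Nc1ccccc1)C1CCN(C/C=C/c2ccccc2)CC1` gives 57900 nM, compound 2 `Cc1ccc(NC(=O)C2CCN(C/C=C/c3ccccc3)CC2)cc1` gives 24100 nM, and compound 3 `COc1ccc(NC(=O)C2CCN(C/C=C/c3ccccc3)CC2)cc1` gives 58200 nM. Compound 3 therefore sits level with compound 1, while compound 2 is the strongest inhibitor of the three. Compound 4 `COc1cccc(NC(=O)C2CCN(C/C=C/c3ccccc3)CC2)c1` has the same atoms as compound 3, joined differently: 3-methoxyphenyl in place of 4-methoxyphenyl on an amide-type nitrogen. Going by the values given here, no measured step shows a group changing place, so the evidence is indirect. Methoxy in place of hydrogen gave a 1.0-fold higher number from compound 1 to compound 3 (0.00 log units; within the scatter), methyl in place of hydrogen gave a 2.4-fold lower number from compound 1 to compound 2 (0.38 log units; beyond the scatter), and methoxy in place of methyl gave a 2.4-fold higher number from compound 2 to compound 3 (0.38 log units; beyond the scatter). These steps are small, so no change beyond the scatter is expected in this assay. The expected step is a 1.2-fold lower number from compound 3 to compound 4 (0.07 log units; within the scatter). Compound 4 is estimated at 50000 nM, with an expected range of 22000 nM to 100000 nM.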

Compound 4, half-maximal inhibitory concentration: 37200 nM
For compound 4 the middle estimate is 1.3-fold (0.13 log units) above the measured one; measured number inside the range.
By their numbers in this assay, from the lowest: compounds 2, 4, 1 and 3 (each within the scatter of the next, the first and the last beyond it).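

Shifting the methoxy group gives a 1.6-fold lower number from compound 3 to compound 4 (0.19 log units; within the scatter) in this assay, so 3-methoxyphenyl and 4-methoxyphenyl on the amide-type nitrogen cannot be told apart here. The steps to the two other compounds are a 1.6-fold lower number from compound 1 to compound 4 (0.19 log units; within the scatter) and a 1.5-fold higher number from compound 2 to compound 4 (0.19 log units; within the scatter) and so compound 4 cannot be separated from either of them. Unlike compound 3, which stands beyond the scatter from compound 2, it overlaps all three.

On these data alone, whether an amine or a carboxylic acid in place of the methoxy group would give a step beyond the scatter stays open. No measured property here accounts for these steps.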